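Swapping hydroxymethyl for phenyl on a low-scoring compound

The source may report more compounds than this note shows. Statements on the series, on what has been measured and on what is new or still open speak of the compounds shown alone.

- compound 1 `C=CCc1cc(O)c(O)c(CN2CCC(CCO)CC2)c1` gives 15.3%
- compound 2 `C=CCc1ccc(OCc2cn(-c3ccc(C#N)cc3)nn2)c(O)c1` gives 37.5%
- compound 3 `C=CCc1ccc(OCc2cn(-c3ccccc3Cl)nn2)c(O)c1` gives 10.2%

All three numbers come from a functional assay on SK-N-SH cells (Homo sapiens) for inhibition, read by MTT assay, with a stated time of 72 h, tested at 30 uM; a higher number here means more inhibition of growth at the concentration tested, a lower number less inhibition of growth. Compound 1 and compound 3 lie within the usual scatter of each other and cannot be told apart, while compound 2 stands clearly above compound 1.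

Compound 4 `C=CCc1cc(O)c(O)c(CN2CCC(Cc3ccccc3)CC2)c1` keeps the core of compound 1 and changes one group: phenyl in place of hydroxymethyl on a saturated chain carbon bound to a saturated ring carbon. This is phenyl in place of hydroxymethyl on a saturated chain carbon bound to a saturated ring carbon or, cut one bond further out, 2-hydroxyethyl to benzyl.

Among the measured compounds shown here, only one step between measured compounds is available: a number 27.3 percentage points lower from compound 2 to compound 3 (beyond the scatter). That swap involves different groups in a different place, so it does not test this change. For the measured compounds named here, it shows only that exchanging a single group can shift this read-out by a modest amount. Since compound 1 gives only 15.3%, there is little room for a fall, so a modest rise seems more likely, although a result within the scatter remains possible. The expected step is a number 14.7 percentage points higher from compound 1 to compound 4 (beyond the scatter). For compound 4 the estimated value is 30%, with an expected range from 10% to 60%.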

Compound 4, percent growth inhibition at one concentration: 78.8%
Compound 4: the middle estimate sits 48.8 percentage points below what was measured, and the stated range ends below it.
By their numbers in this assay, from the lowest: compounds 3 and 1 (each within the scatter of the next); then compound 2; then compound 4.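

In this assay, replacing 2-hydroxyethyl with benzyl gives a number 63.5 percentage points higher from compound 1 to compound 4 (beyond the scatter), so the group on this saturated ring carbon can have a large effect on growth inhibition at the concentration tested. The earlier compounds shown here offered only a number 27.3 percentage points lower from compound 2 to compound 3 (beyond the scatter), a step at a different place with different groups, and could not show that this part of the core of compound 1 responds so strongly to a change. Nothing measured here explains why the number rises, so the result records the effect of the swap but not its cause.

This single swap removes hydroxymethyl and brings in phenyl at once, with its six-membered aromatic ring of carbon only, so the compounds shown cannot separate the loss of one group from the gain of the other. A propyl chain or a cyclohexylmethyl group in the same place would help to separate them, while 2-phenylethyl would ask whether the length of the chain carrying the phenyl matters.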